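Swapping the trimethoxyphenyl arm: what to expect for compound 4

The compounds below may be only part of what the source reports. "The series", "measured", "known", "first", "only" and "open" are said of these compounds alone.

Measured in a functional assay on B16-F10 cells (Mus musculus) for inhibition, read by MTT assay, with a stated time of 72 h; on this read-out higher numbers stand for weaker inhibition and lower numbers for stronger inhibition:
compound 1 `COc1cc(-c2nc(SCc3cn(CC(=O)NC(=O)Nc4ccccn4)nn3)nc(Nc3cccc(C(F)(F)F)c3)c2C#N)cc(OC)c1OC` gives 24400 nM
compound 2 `COc1cc(-c2nc(SCc3cn(CC(=O)NC(=O)Nc4ccccn4)nn3)nc(Nc3ccc(Cl)cc3)c2C#N)cc(OC)c1OC` gives 1110 nM
compound 3 `COc1cc(-c2nc(SCc3cn(CC(=O)NC(=O)Nc4ccccn4)nn3)nc(Nc3cccc(Cl)c3)c2C#N)cc(OC)c1OC` gives 1420 nM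

Compound 3 holds the second highest of the three numbers. Its nearest neighbour is compound 2: a 1.3-fold higher number from compound 2 to compound 3 (0.11 log units; within the scatter), so the two cannot be told apart. Its furthest partner is compound 1: a 17-fold lower number from compound 1 to compound 3 (1.24 log units; beyond the scatter), a clear gap. Compound 4 `Cc1ccc(-c2nc(SCc3cn(CC(=O)NC(=O)Nc4ccccn4)nn3)nc(Nc3cccc(Cl)c3)c2C#N)cc1` has not been measured yet. The change from compound 3 to compound 4 is 4-methylphenyl in place of 3,4,5-trimethoxyphenyl on an aromatic carbon. Within the data shown here, every measured step so far (a 22-fold lower number from compound 1 to compound 2 (1.34 log units; beyond the scatter), a 17-fold lower number from compound 1 to compound 3 (1.24 log units; beyond the scatter), a 1.3-fold higher number from compound 2 to compound 3 (0.11 log units; within the scatter)) alters only the ring sitting on the nitrogen, and none touches the group exchanged here. Among the measured compounds shown here, no measured step therefore bears on this change, and neither its direction nor its size in this assay can be read from the data. The estimate starts from compound 3 with its 1420 nM and carries a wide range. Compound 4 is expected to give 3500 nM, between 800 nM and 16000 nM. This corresponds to an expected step of a 2.5-fold higher number from compound 3 to compound 4 (0.39 log units; beyond the scatter).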

Compound 4, half-maximal inhibitory concentration: 7580 nM
Compound 4: the middle estimate sits 2.2-fold (0.34 log units) below what was measured, within the range that was stated.
By their numbers in this assay, from the lowest: compounds 2 and 3 (each within the scatter of the next); then compound 4; then compound 1.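

In this assay, the exchange of 3,4,5-trimethoxyphenyl for 4-methylphenyl gives a 5.3-fold higher number from compound 3 to compound 4 (0.73 log units; beyond the scatter) and is the first step shown at the aromatic carbon next to the ring nitrogen, so the number depends on this group as well as on the ring sitting on the nitrogen. The exchange changes several things at once, going from 12 heavy atoms to 7 and from 3 hydrogen-bond acceptors to 0, so this single step cannot assign the loss to any one of them. No measurement here offers an explanation for the step.

The compounds shown leave open whether a 4-methoxyphenyl or a plain phenyl at this position would fall closer to compound 3 or compound 4. They also leave open whether the same exchange would have a similar effect with the 4-chlorophenyl of compound 2 on the nitrogen.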